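This account rests on a few compounds, and the source may have more. Where it says the series, first, only, none or still open, it means among the compounds named here.

Compound 2 `N#Cc1ccc(-c2nc(N)c3cc(Cc4ccccc4)sc3n2)o1` gives 3160 nM in a functional assay on CHO-K1 cells for antagonist activity at adenosine receptor A1 (Homo sapiens), read by a beta-galactosidase reporter and cAMP accumulation, with stated times of 15 min and 6 h (a lower number here means a stronger inhibitor, a higher number a weaker inhibitor), and stands highest among the three measured numbers: compound 3 `Cc1csc(-c2nc(N)c3cc(Cc4ccccc4Cl)sc3n2)n1` gives 49.6 nM and compound 1 `Cc1ccc(-c2nc(N)c3cc(Cc4ccccc4Cl)sc3n2)o1` gives 26.1 nM, both far lower and beyond the scatter. Compound 4 `Nc1nc(-c2cccnc2)nc2sc(Cc3ccccc3)cc12` differs from compound 2 by pyridin-3-yl in place of 5-cyanofuran-2-yl on an aromatic carbon. Going by the values given here, the only measured step at this position, a 1.9-fold higher number from compound 1 to compound 3 (0.28 log units; within the scatter), swaps one five-membered heteroaryl for another and stays within the scatter; it says little about a six-membered ring entering in place of the 5-cyanofuran-2-yl group, and nothing measured separates that group from the 5-methylfuran-2-yl of compound 1. The estimate for compound 4 is therefore a 4.0-fold lower number from compound 2 to compound 4 (0.60 log units; beyond the scatter), a modest move toward a lower number with wide uncertainty, giving compound 4 an expected 800 nM within 150 nM to 4000 nM.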

Compound 4, inhibition constant: 1420 nM
Estimate against measurement, compound 4: 1.8-fold (0.25 log units) below; measured number inside the range.
By their numbers in this assay, from the lowest: compounds 1 and 3 (each within the scatter of the next); then compound 4; then compound 2.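

A six-membered aromatic ring can stand at this position in place of the five-membered 5-cyanofuran-2-yl, and the number falls modestly but beyond the scatter (a 2.2-fold lower number from compound 2 to compound 4 (0.35 log units; beyond the scatter)). The earlier step had only exchanged one five-membered heteroaryl for another, whereas this change also removes the nitrile, so this single step cannot separate the effect of the ring from that of the nitrile. No evidence here bears on why the number moved. From the compounds shown here alone, it remains open how a methyl or an amine on the pyridin-3-yl would shift the number, and how pyridin-2-yl or pyridin-4-yl would compare.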